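Swapping the halogenated methoxyphenyl group: from compound 3 to compound 4

The compounds below may be only part of what the source reports. "The series", "measured", "known", "first", "only" and "open" are said of these compounds alone.

Measured so far:
compound 1 `COc1cc(NC(=O)Nc2cc(Nc3ccc(C)c(C)c3)ncn2)cc(OC)c1` gives 20.1%
compound 2 `COc1cc(NC(=O)Nc2cc(Nc3ccc(C)c(F)c3)ncn2)cc(OC)c1` gives 38%
compound 3 `COc1cc(NC(=O)Nc2cc(Nc3cc(I)ccc3OC)ncn2)cc(OC)c1` gives 59%

In a functional assay on NCI-H1581 cells (Homo sapiens) for inhibition, read by MTT assay, with a stated time of 48 h, tested at 10 uM (on this read-out lower numbers stand for less inhibition and higher numbers for more inhibition at the one concentration tested (going by the name of the read-out)), compound 3 gives the highest of the three numbers, with a number 21 percentage points higher from compound 2 to compound 3 (beyond the scatter) and a number 38.9 percentage points higher from compound 1 to compound 3 (beyond the scatter). Compound 4 `COc1cc(NC(=O)Nc2cc(Nc3ccc(Br)cc3OC)ncn2)cc(OC)c1` differs from compound 3 by 4-bromo-2-methoxyphenyl in place of 5-iodo-2-methoxyphenyl on a nitrogen on an aromatic ring. For the measured compounds named here, no measured step covers this exact exchange of one halogen and its position for another. The nearest guide is a number 17.9 percentage points higher from compound 1 to compound 2 (beyond the scatter), where one small substituent replaced another on the same ring. Both rings carrying a methoxy group so far beat the others, so compound 4 is expected to stay in the upper part of the range, with a step of a number 9 percentage points lower from compound 3 to compound 4 (within the scatter) expected. The estimate for compound 4 is 50%, between 25% and 75%.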

Compound 4, a percentage reported as inhibition, at one concentration (the size of the read-out at that concentration, not a potency): 20.1%
The estimate for compound 4 lay 29.9 percentage points above the measured number; measured number outside the range, below it.
By their numbers in this assay, from the lowest: compounds 1 and 4 (each within the scatter of the next); then compound 2; then compound 3.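

In this assay, a methoxy group on this ring does not by itself keep the number high: exchanging 5-iodo-2-methoxyphenyl for 4-bromo-2-methoxyphenyl gives a number 38.9 percentage points lower from compound 3 to compound 4 (beyond the scatter). The same ring also falls short of 3-fluoro-4-methylphenyl, with a number 17.9 percentage points lower from compound 2 to compound 4 (beyond the scatter), and against 3,4-dimethylphenyl there is no change at the digits printed from compound 1 to compound 4 (within the scatter). Nothing measured here explains this. On these data alone, the halogen and its position change together, so which of the two matters remains open. Also open, as far as these compounds go, is how an amine or a carboxylic acid in place of the halogen would read.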